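The source may hold more compounds than are shown below. What is called first, only, known or untested is meant among the compounds shown, and "the series" means these compounds.

Measured compounds in a functional assay on PC-3 cells (Homo sapiens) for cytotoxicity, read by MTT assay, with a stated time of 72 h; on this read-out lower numbers stand for stronger inhibition and higher numbers for weaker inhibition:

- compound 1, `CCCCCCNc1nc(SCc2ccc(C(F)(F)F)cc2)nc2ccccc12`, gives 19000 nM
- compound 2, `FC(F)(F)c1ccc(CSc2nc(Nc3ccccc3Cl)c3ccccc3n2)cc1`, gives 20400 nM
- compound 3, `O=[N+]([O-])c1ccc(Nc2nc(SCc3ccc(C(F)(F)F)cc3)nc3ccccc23)cc1`, gives 7900 nM

Compound 2 holds the highest number of the three. Its nearest neighbour is compound 1, the gap being a 1.1-fold higher number from compound 1 to compound 2 (0.03 log units; within the scatter). Compound 3 stands furthest away, with a 2.6-fold lower number from compound 2 to compound 3 (0.41 log units; beyond the scatter).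

Compound 4, `Cc1ccc(Nc2nc(SCc3ccc(C(F)(F)F)cc3)nc3ccccc23)cc1`, is not yet measured. Relative to compound 2 the change is 4-methylphenyl in place of 2-chlorophenyl on a nitrogen on an aromatic ring.

Among the measured compounds shown here, only one measured step exchanges one aryl group for another on this nitrogen: a 2.6-fold lower number from compound 2 to compound 3 (0.41 log units; beyond the scatter), a modest shift. The step of a 2.4-fold lower number from compound 1 to compound 3 (0.38 log units; beyond the scatter) points the same way, whereas a 1.1-fold higher number from compound 1 to compound 2 (0.03 log units; within the scatter) lies within the scatter. For the measured compounds named here, no measured step involves 4-methylphenyl, so the direction for compound 4 rests on analogy alone.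

For compound 4 the expectation is a step of a 1.5-fold lower number from compound 2 to compound 4 (0.16 log units; within the scatter) in this assay, a modest move toward a lower number but smaller than the step to compound 3, with wide uncertainty. The estimate for compound 4 is 14000 nM, within the range 6000 nM to 32000 nM.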

Compound 4, half-maximal inhibitory concentration: 21100 nM
Compound 4: the middle estimate sits 1.5-fold (0.18 log units) below what was measured; the range from low to high includes it.
By their numbers in this assay, from the lowest: compound 3; then compounds 1, 2 and 4 (each within the scatter of the next).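

In this assay, 4-methylphenyl and 2-chlorophenyl on this nitrogen cannot be told apart, with a 1.0-fold higher number from compound 2 to compound 4 (0.01 log units; within the scatter), and the same holds for 4-methylphenyl and hexyl, with a 1.1-fold higher number from compound 1 to compound 4 (0.05 log units; within the scatter). Among the compounds shown here, an aryl group here therefore does not by itself go with a lower number, and the one single-place exchange on the aromatic carbon, methyl in place of nitro, gives a 2.7-fold higher number from compound 3 to compound 4 (0.43 log units; beyond the scatter), leaving compound 3 as the only compound set apart from the other three. No measurement at hand accounts for this separation.

The compounds shown leave open whether the lower number is particular to 4-nitrophenyl or also appears with 4-cyanophenyl, 4-aminophenyl or 4-carboxyphenyl on this nitrogen. They also leave open whether a chain shorter or longer than hexyl would separate from compound 1.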